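Substituent swap on the aryl ring: isopropyl to chloro

The source may hold more compounds than are shown below. What is called first, only, known or untested is meant among the compounds shown, and "the series" means these compounds.

Compound 1 `C=CCCCCOc1ncc(-c2ccccc2OC)n1C` is the parent of the pair; in a functional assay on SK-MEL-28 cells (Homo sapiens) for inhibition, read by colorimetric assay and MTT assay, with a stated time of 72 h (on this read-out lower numbers stand for stronger inhibition and higher numbers for weaker inhibition), compound 1 gives 13000 nM. Compound 2 `C=CCCCCOc1ncc(-c2cc(C(C)C)ccc2OC)n1C` carries an isopropyl on the aromatic ring, and in this assay compound 2 gives 3000 nM. Among the measured compounds shown here, the only measured step, a 4.3-fold lower number from compound 1 to compound 2 (0.64 log units; beyond the scatter), is modest but beyond the scatter, and compound 2 therefore stands with the lowest number of the two.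

Compound 3 `C=CCCCCOc1ncc(-c2cc(Cl)ccc2OC)n1C` differs from compound 2 by chloro in place of isopropyl on an aromatic carbon, sitting meta to a large group and para to the methoxy group. For the measured compounds named here, the one step that bears on this site shows the isopropyl worth a modest gain over hydrogen, and chloro has no measured counterpart here; a change partway back toward compound 1 is the expectation, a 2.0-fold higher number from compound 2 to compound 3 (0.30 log units; within the scatter), with wide uncertainty. For compound 3 in this assay the expected value is 6000 nM, within a range of 2500 nM to 15000 nM.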

Compound 3, half-maximal inhibitory concentration: 28000 nM
Beside the measured number, compound 3's estimate is 4.7-fold (0.67 log units) below it; the whole stated range lies below it.
By their numbers in this assay, from the lowest: compound 2; then compound 1; then compound 3.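

In this assay this position responds in both directions: chloro in place of isopropyl gives a 9.3-fold higher number from compound 2 to compound 3 (0.97 log units; beyond the scatter) and chloro in place of hydrogen gives a 2.2-fold higher number from compound 1 to compound 3 (0.33 log units; beyond the scatter) on the same carbon. Among the compounds shown here, a substituent at this carbon is therefore no gain in itself, as the single isopropyl step might have suggested: isopropyl lowers the number relative to hydrogen, chloro raises it, and compound 3 is the weakest of the three. Nothing measured here accounts for the opposite outcomes of the two groups.

As far as these compounds go, whether the gain is particular to isopropyl remains open, and methyl, tert-butyl or methoxy on the same carbon would test that. Also open, from the compounds shown here alone, is whether the order of hydrogen, isopropyl and chloro holds when a shorter chain replaces the ether chain of the shared core.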